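A Second Benzyl on the Aniline Nitrogen

A few compounds are considered here, and "the series" means these few. Any claim that something is new, unique, unknown or untested is made for them only; others in the source may bear on it.

Compound 1 `COc1cc(OC)n2cc(-c3ccc([N+](=O)[O-])cc3)nc2n1` carries a nitro group on the pendant aromatic ring of the shared core, and in a functional assay on HepG2 cells (Homo sapiens) for antiproliferative activity, read by MTT assay, with a stated time of 72 h (on this read-out lower numbers stand for stronger inhibition of growth and higher numbers for weaker inhibition of growth), compound 1 gives 35900 nM. Compound 2 `CNc1ccc(-c2cn3c(OC)cc(OC)nc3n2)cc1` has methylamino in place of nitro on an aromatic carbon. In this assay compound 2 reaches only a limit of the assay, > 100000 nM. The step is an at least 2.7-fold higher number from compound 1 to compound 2 (0.44 log units; beyond the scatter). Compound 3 `COc1cc(OC)n2cc(-c3ccc(NCc4ccccc4)cc3)nc2n1` has benzylamino in place of nitro on the same aromatic carbon. In this assay compound 3 also sits at a limit of the assay, > 100000 nM. Hence an at least 2.7-fold higher number from compound 1 to compound 3 (0.44 log units; beyond the scatter), while a step that the two limits leave unreadable from compound 2 to compound 3. Compound 3 thus stands at the limit of > 100000 nM in this assay, at which 2 of the 3 values shown sit, among the weakest results shown.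

Compound 4 `COc1cc(OC)n2cc(-c3ccc(N(Cc4ccccc4)Cc4ccccc4)cc3)nc2n1` differs from compound 3 by benzyl in place of hydrogen on a nitrogen on an aromatic ring. Going by the values given here, no measured step touches this nitrogen directly: the change from hydrogen to phenyl on the chain carbon, from compound 2 to compound 3, is not readable, and the two readable steps concern the exchange of nitro for an amine. The account therefore expects that compound 4 again yields no readable number in this assay and that the estimated step that the limit leaves unreadable from compound 3 to compound 4 stays within the scatter. For compound 4 the expected value is 150000 nM, with a range from 50000 nM to 500000 nM.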

Compound 4, concentration for 50% growth inhibition: > 100000 nM
Compound 4 was reported as a limit; the forecaster's own chance of this, stated with the estimate: 75%; the middle value lies beyond the limit too.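

In this assay compound 4 gives > 100000 nM, which is a limit of the assay. Compound 3 is at a limit too, so no step can be read between compound 3 and compound 4: the limit of > 100000 nM in this assay, at which 3 of the 4 values shown sit. The compounds shown leave open whether the second benzyl on the nitrogen changes growth inhibition at all.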